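Sulfur-linked substituents on the shared core: expectation for compound 4

A few compounds are considered here, and "the series" means these few. Any claim that something is new, unique, unknown or untested is made for them only; others in the source may bear on it.

compound 1 `Cc1cc(Nc2cc(-c3ccccc3)[nH]n2)n2nc(SCc3c(Cl)cccc3Cl)nc2n1`: 3230 nM
compound 2 `Cc1cc(Nc2cc(-c3ccccc3)[nH]n2)n2nc(SCc3ccc(C(F)(F)F)cc3)nc2n1`: 4820 nM
compound 3 `Cc1cc(Nc2cc(-c3ccccc3)[nH]n2)n2nc(SCc3cccc4ccccc34)nc2n1`: 7560 nM

In a functional assay on MCF7 cells (Homo sapiens) for inhibition, read by MTT assay, with a stated time of 72 h (on this read-out higher numbers stand for weaker inhibition and lower numbers for stronger inhibition), compound 3 stands at the highest of the three numbers. Its separation from compound 1 is a 2.3-fold higher number from compound 1 to compound 3 (0.37 log units; beyond the scatter), and its separation from compound 2 is a 1.6-fold higher number from compound 2 to compound 3 (0.20 log units; within the scatter), so only the gap to compound 1 counts as a real difference.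

Compound 4 `Cc1cc(Nc2cc(-c3ccccc3)[nH]n2)n2nc(SCC3CCCCC3)nc2n1` differs from compound 3 by cyclohexyl in place of naphthalen-1-yl on a saturated chain carbon bound to a sulfur. All three measured steps sit at this same place, but each exchanges one aromatic group for another: a 1.5-fold higher number from compound 1 to compound 2 (0.17 log units; within the scatter), a 2.3-fold higher number from compound 1 to compound 3 (0.37 log units; beyond the scatter), a 1.6-fold higher number from compound 2 to compound 3 (0.20 log units; within the scatter). Going by the values given here, none exchanges an aromatic group for a non-aromatic ring, so the move to compound 4 has no direct precedent among the measured compounds. The measured steps at this position are small, so a shift within the scatter, or at most a modest rise in the number, is the expectation; the expected step is a 1.3-fold higher number from compound 3 to compound 4 (0.10 log units; within the scatter). Compound 4 is estimated at 9500 nM, with an expected range from 4000 nM to 22000 nM.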

Compound 4, half-maximal inhibitory concentration: > 50000 nM
Compound 4: a limit, no number; the forecaster's own chance of this, stated with the estimate: 15%; middle value at least 5.2-fold (0.72 log units) from the limit.
By their numbers in this assay, from the lowest: compounds 1, 2 and 3 (each within the scatter of the next, the first and the last beyond it). At a limit, above all of these: compound 4.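

In this assay, compound 4 stands at a limit of the assay and gives no number: the limit of > 50000 nM in this assay, at which 1 of the 4 values shown sits.

Replacing each aromatic group with cyclohexyl on a saturated chain carbon bound to a sulfur gives an at least 6.6-fold higher number from compound 3 to compound 4 (0.82 log units; beyond the scatter), an at least 10-fold higher number from compound 2 to compound 4 (1.01 log units; beyond the scatter) and an at least 15-fold higher number from compound 1 to compound 4 (1.18 log units; beyond the scatter). The widest step among the aromatic groups is a 2.3-fold higher number from compound 1 to compound 3 (0.37 log units; beyond the scatter), so in these four compounds this position tolerates exchange of one aromatic group for another far better than the move to this non-aromatic ring.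

With only one non-aromatic ring shown, it remains open whether the loss belongs to cyclohexyl alone or to non-aromatic groups at this place generally. A piperidine ring or a longer alkyl chain on the same sulfur would help separate these two readings.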